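Swapping a ring amine for diisopropylamino on a dithiocarbamate

This account rests on a few compounds, and the source may have more. Where it says the series, first, only, none or still open, it means among the compounds named here.

Compound 1, `O=c1cc(CSC(=S)N2CCCCC2)oc2cc(Cl)ccc12`: 3000 nM
Compound 2, `O=c1c(CSC(=S)N2CCOCC2)coc2cc(Cl)ccc12`: 600 nM
Compound 3, `COc1ccc2occ(CSC(=S)N(C(C)C)C(C)C)c(=O)c2c1`: 1800 nM

Of the compounds shown here, three have been measured in a functional assay on MDA-MB-435S cells (Homo sapiens) for antiproliferative activity, read by MTT assay, with a stated time of 72 h; a lower number here means a stronger inhibitor, a higher number a weaker inhibitor. Compound 1 gives the highest of the three numbers. Compound 3 sits close to it, a gap inside the usual scatter, while compound 2 lies beyond the scatter with a lower number. Compound 4, `CC(C)N(C(=S)SCc1cc(=O)c2ccc(Cl)cc2o1)C(C)C`, has not yet been measured. It keeps the core of compound 1 and differs in one place: diisopropylamino in place of piperidin-1-yl on a thiocarbonyl carbon. Within the data shown here, no measured pair shows this exact change, so its size is unknown. Compound 3 also carries diisopropylamino, on another core, and its number lies close to that of compound 1, so no step beyond the scatter in this assay is expected. Compound 4 is expected to give 2200 nM, between 800 nM and 6000 nM. The expected step of a 1.4-fold lower number from compound 1 to compound 4 (0.13 log units; within the scatter) is small.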

Compound 4, half-maximal inhibitory concentration: > 25000 nM
Compound 4 ended at the assay's limit; the forecaster's own chance of this, stated with the estimate: 5%; middle value at least 11-fold (1.05 log units) away from the limit.
By their numbers in this assay, from the lowest: compound 2; then compounds 3 and 1 (each within the scatter of the next). At a limit, above all of these: compound 4.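

In this assay, compound 4 gives > 25000 nM, which is a limit of the assay and not a number. The earlier compounds shown here offered no pair differing in one place, and this first pair gives an at least 8.3-fold higher number from compound 1 to compound 4 (0.92 log units; beyond the scatter), so on the core of compound 1 the group on the thiocarbonyl carbon matters: diisopropylamino cannot stand in for piperidin-1-yl here.

On these data alone, compound 3 carries diisopropylamino on another core without a piperidin-1-yl partner, so whether the step holds there stays open. Also open, as far as these compounds go, is how pyrrolidin-1-yl or dimethylamino would fare at this place.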